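The source may hold more compounds than are shown below. What is called first, only, known or untested is meant among the compounds shown, and "the series" means these compounds.

Measured so far:
- Compound 1 `CCc1cccc(NC(=O)c2cccc(/C=C3\CC(=O)N(Cc4ccccc4)C3=O)c2)c1` — in an ADME assay on NCM460 cells (Homo sapiens) for cytotoxicity, read by MTT assay, with a stated time of 72 h (on this read-out lower numbers stand for stronger inhibition and higher numbers for weaker inhibition), compound 1 gives > 100000 nM, a limit of the assay rather than a number.
- Compound 2 `Cc1ccc(NC(=O)c2cccc(/C=C3\CC(=O)N(c4ccccc4)C3=O)c2)cc1C` — in this assay compound 2 gives > 100000 nM, again a limit of the assay and not a number.

Compound 2 therefore stands at the limit that both values shown share: the limit of > 100000 nM in this assay, at which 2 of the 2 values shown sit. For the measured compounds named here, neither compound has yielded a number in this assay, so no measured step between them can be sized, and the two values only show that both sit at the limit.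

Compound 3 `O=C(NCc1ccccc1)c1cccc(/C=C2\CC(=O)N(c3ccccc3)C2=O)c1` differs from compound 2 in one place: benzyl in place of 3,4-dimethylphenyl on an amide-type nitrogen. Going by the values given here, no step touching this change has been measured. Given that compound 2 gives > 100000 nM in this assay, a step from compound 2 to compound 3 of about a step that the limit leaves unreadable from compound 2 to compound 3 is expected, that is, none beyond the scatter in either direction. For compound 3 in this assay a value near 150000 nM is estimated, within 50000 nM to 500000 nM, most likely reported again as a limit.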

Compound 3, half-maximal inhibitory concentration: > 100000 nM
Compound 3 gave a limit, no number (the forecaster's own chance of this, stated with the estimate: 85%); the middle value lies beyond the limit too.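

Compound 2 and compound 3 both give limits rather than numbers in this assay, so no step between them can be read: the limit of > 100000 nM in this assay, at which 3 of the 3 values shown sit.

The compounds shown leave open how benzyl and 3,4-dimethylphenyl on the amide-type nitrogen compare in this assay.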